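The source may report more compounds than this note shows. Statements on the series, on what has been measured and on what is new or still open speak of the compounds shown alone.

The three measured compounds share one core and differ only in the group on the amide-type nitrogen. Compound 1 `CC(C)[C@H](C(=O)NCc1ccccc1)c1ccc(Cl)cc1` carries a benzyl group there; in a functional assay on CHO cells for agonist activity at Free fatty acid receptor 2 (Homo sapiens), read by cAMP accumulation (on this read-out lower numbers stand for stronger inhibition and higher numbers for weaker inhibition), compound 1 gives only the assay limit of > 100000 nM (the limit of > 100000 nM in this assay, at which 1 of the 3 values shown sits). Compound 2 `CC(C)C(C(=O)Nc1ncccn1)c1ccc(Cl)cc1` carries a pyrimidin-2-yl group and gives 53000 nM in this assay. Compound 3 `CC(C)[C@H](C(=O)Nc1ncns1)c1ccc(Cl)cc1` carries a 1,2,4-thiadiazol-5-yl group and gives 2000 nM in this assay. Among the numbers shown, compound 2 stands highest, with compound 3 the nearest and clearly apart. Within the data shown here, the only single-point step measured, an at least 50-fold lower number from compound 1 to compound 3 (1.69 log units; beyond the scatter), shows that the group on the amide-type nitrogen can move the number a long way. Compound 4 `CC(C)C(C(=O)Nc1nnn[nH]1)c1ccc(Cl)cc1` is the unmeasured partner of compound 2: 1H-tetrazol-5-yl in place of pyrimidin-2-yl on an amide-type nitrogen. Compound 3, with one five-membered aromatic ring on the amide-type nitrogen, gives 2000 nM, and compound 2, with a six-membered ring there, gives 53000 nM. On that basis a lower number is expected for compound 4, with the expected step being an 8.8-fold lower number from compound 2 to compound 4 (0.95 log units; beyond the scatter). Compound 4 is estimated at 6000 nM, within a range from 800 nM to 45000 nM.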

Compound 4, half-maximal inhibitory concentration: 100000 nM
Estimate against measurement, compound 4: 17-fold (1.22 log units) below; measured number above the stated range.
By their numbers in this assay, from the lowest: compound 3; then compounds 2 and 4 (each within the scatter of the next).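

In this assay, 1H-tetrazol-5-yl in place of pyrimidin-2-yl on the amide-type nitrogen gives a 1.9-fold higher number from compound 2 to compound 4 (0.28 log units; within the scatter), so the number does not move beyond the scatter, even though ring size, hetero atoms and hydrogen-bond donors all differ. A five-membered aromatic ring at this position therefore does not by itself go with a low number: compound 3 gives 2000 nM, and compound 4 goes against that reading. Compound 4 also sits at the same figure as compound 1, whose value is a limit of the assay and not a number: the limit of > 100000 nM in this assay, at which 1 of the 4 values shown sits.

Which feature of the 1,2,4-thiadiazol-5-yl group goes with the lower number of compound 3 remains open. The compounds shown include no close relative of that group, such as 1,3-thiazol-2-yl or 1,3,4-thiadiazol-2-yl, and no pyridin-2-yl to set beside pyrimidin-2-yl.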